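A few compounds are considered here, and "the series" means these few. Any claim that something is new, unique, unknown or untested is made for them only; others in the source may bear on it.

Three compounds of the shared core have been run in an assay on isolated protein (Mus musculus) for inhibition of IL15-IL15 receptor (Homo sapiens), read by resazurin assay, with stated times of 30 min and 2.5 days; on this read-out lower numbers stand for stronger inhibition and higher numbers for weaker inhibition. Compound 1 `CCCOc1ccc(NC(=O)CSc2nnc(Cc3nn(C)c(=O)c4ccccc34)n2C)cc1` reaches only the limit of > 30000 nM. Compound 2 `CN(C(=O)CSc1nnc(Cc2nn(C)c(=O)c3ccccc23)n1C)c1ccc(Cl)cc1Cl` likewise gives no number but the limit of > 30000 nM. Going by the values given here, compound 3 `Cn1c(Cc2nn(C)c(=O)c3ccccc23)nnc1SCC(=O)Nc1ccc(Cl)cc1Cl` gives 17300 nM, the only finite number among the three. The steps of an at least 1.7-fold lower number from compound 1 to compound 3 (0.23 log units; that floor lies within the scatter) and an at least 1.7-fold lower number from compound 2 to compound 3 (0.23 log units; that floor lies within the scatter) are floors only, set by the limit of > 30000 nM in this assay, at which 2 of the 3 values shown sit, and both lie within the scatter. Compound 4 `Cn1c(Cc2nn(C)c(=O)c3ccccc23)nnc1SCC(=O)Nc1ccc(Br)cc1Br` carries 2,4-dibromophenyl in place of 2,4-dichlorophenyl on an amide-type nitrogen. Among the compounds with values here, no measured step exchanges one halogen pair for another on this ring, so the change has no precedent. Compound 4 is therefore expected to land near its neighbour, the expected step being a 1.0-fold lower number from compound 3 to compound 4 (0.01 log units; within the scatter) in this assay. Compound 4 is estimated at 17000 nM, between 8000 nM and 40000 nM.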

Compound 4, half-maximal inhibitory concentration: > 30000 nM
Compound 4 gave a limit, no number (the forecaster's own chance of this, stated with the estimate: 40%); middle value at least 1.7-fold (0.24 log units) from the limit.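

In this assay, going by these compounds alone, the first exchange of one halogen pair for another on this ring, 2,4-dibromophenyl in place of 2,4-dichlorophenyl, gives an at least 1.7-fold higher number from compound 3 to compound 4 (0.23 log units; that floor lies within the scatter). This is a floor only, so the change is not shown to matter beyond the scatter, and compound 3 remains the only compound with a number. The steps to compound 4 from compound 1 and compound 2 cannot be read, because both ends are limits: the limit of > 30000 nM in this assay, at which 3 of the 4 values shown sit.

Still open, on these data alone, is whether 2,4-difluorophenyl or 4-chlorophenyl on the same nitrogen would give a number. As far as these compounds go, the effect of changing the shared core also remains open.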